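A few compounds are considered here, and "the series" means these few. Any claim that something is new, unique, unknown or untested is made for them only; others in the source may bear on it.

Of the compounds shown here, three sharing one core have been measured in a functional assay for inhibition of sodium/hydrogen exchanger (Oryctolagus cuniculus); on this read-out higher numbers stand for weaker inhibition and lower numbers for stronger inhibition. Compound 1 `Cc1cc(C2CCC2)c(S(C)(=O)=O)cc1C(=O)N=C(N)N` carries a cyclobutyl group, and compound 1 gives 8.2 nM. Compound 2 `Cc1cc(-c2cc(Cl)cc(Cl)c2)c(S(C)(=O)=O)cc1C(=O)N=C(N)N` bears a 3,5-dichlorophenyl group in that place, and compound 2 gives 130 nM; the step of a 16-fold higher number from compound 1 to compound 2 (1.20 log units; beyond the scatter) is the largest seen here. Compound 3 `Cc1cc(Sc2ccc(Cl)cc2)c(S(C)(=O)=O)cc1C(=O)N=C(N)N` carries a (4-chlorophenyl)sulfanyl group, and compound 3 gives 19 nM, the second highest of the three numbers: its nearest neighbour is compound 1, with a 2.3-fold higher number from compound 1 to compound 3 (0.36 log units; beyond the scatter), and its furthest is compound 2, with a 6.8-fold lower number from compound 2 to compound 3 (0.84 log units; beyond the scatter).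

Compound 4 `Cc1cc(N2CCCC(O)C2)c(S(C)(=O)=O)cc1C(=O)N=C(N)N` is not yet measured. It differs from compound 3 in one place: 3-hydroxypiperidin-1-yl in place of (4-chlorophenyl)sulfanyl on an aromatic carbon. Going by the values given here, no measured step exchanges an aromatic group for a non-aromatic ring with a hetero atom, so guidance is indirect: the only non-aromatic substituent, cyclobutyl in compound 1, gave the lowest number, and both aromatic replacements raised it, by a 16-fold higher number from compound 1 to compound 2 (1.20 log units; beyond the scatter) and a 2.3-fold higher number from compound 1 to compound 3 (0.36 log units; beyond the scatter). On that basis compound 4 is expected to show a modestly lower number than compound 3, a 1.3-fold lower number from compound 3 to compound 4 (0.10 log units; within the scatter), with wide uncertainty. The estimate for compound 4 is 15 nM, within 4 nM to 60 nM.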

Compound 4, half-maximal inhibitory concentration: 30 nM
For compound 4 the middle estimate is 2.0-fold (0.30 log units) below the measured one; the range from low to high includes it.
By their numbers in this assay, from the lowest: compound 1; then compounds 3 and 4 (each within the scatter of the next); then compound 2.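

At this aromatic carbon, ortho to a methylsulfonyl group, the change to 3-hydroxypiperidin-1-yl gives a number in this assay that cannot be told apart from that of the (4-chlorophenyl)sulfanyl group (a 1.6-fold higher number from compound 3 to compound 4 (0.20 log units; within the scatter)). A non-aromatic ring at this place therefore does not by itself reproduce the result of cyclobutyl (a 3.7-fold higher number from compound 1 to compound 4 (0.56 log units; beyond the scatter)), although the 3-hydroxypiperidin-1-yl group still stands clear of 3,5-dichlorophenyl (a 4.3-fold lower number from compound 2 to compound 4 (0.64 log units; beyond the scatter)). Nothing available accounts for these steps.

The compounds shown leave open how a plain piperidine, a morpholine or a cyclopentyl ring would read at this carbon, and so whether the hydroxyl of compound 4 shifts its number at all. Going by these compounds, how an open-chain amine such as dimethylamino would compare with these rings also remains open.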